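The source may report more compounds than this note shows. Statements on the series, on what has been measured and on what is new or still open speak of the compounds shown alone.

Measured in an ADME assay on the whole organism (strain Sprague-Dawley) for pharmacokinetics, with Rattus norvegicus as the target, read by LC-MS, using cassette dosing, at a dose of 0.5 mg/kg by the intravenous route; a higher number here means faster removal of the compound, a lower number slower removal:
- Compound 1 `C[C@@]1(c2cc(NC(=O)c3coc(C(F)F)n3)ccc2F)C=C(CF)OC(N)=N1`: 28.4 mL/min/kg
- Compound 2 `C[C@@]1(c2cc(NC(=O)c3cnc(C(F)F)cn3)ccc2F)C=C(CF)OC(N)=N1`: 48.1 mL/min/kg
- Compound 3 `C[C@@]1(c2cc(NC(=O)c3ncc(OCF)nc3N)ccc2F)C=C(CF)OC(N)=N1`: 45.3 mL/min/kg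

Compound 3, at 45.3 mL/min/kg, stands within the scatter of both other compounds. Compound 4 `C[C@@]1(c2cc(NC(=O)c3ccc(C#N)cn3)ccc2F)C=C(CF)OC(N)=N1` differs from it only on the carbonyl carbon, with 5-cyanopyridin-2-yl in place of 3-amino-5-(fluoromethoxy)pyrazin-2-yl (5-cyanopyridin-2-yl in place of 3-amino-5-(fluoromethoxy)pyrazin-2-yl on a carbonyl carbon). Three measured steps change the group at this same place: a 1.7-fold higher number from compound 1 to compound 2 (0.23 log units; within the scatter), a 1.6-fold higher number from compound 1 to compound 3 (0.20 log units; within the scatter) and a 1.1-fold lower number from compound 2 to compound 3 (0.03 log units; within the scatter). All three lie within the scatter, although none involves the 5-cyanopyridin-2-yl group, so their guidance is limited. No step beyond the scatter is therefore expected in this assay. The estimated step is a 1.1-fold lower number from compound 3 to compound 4 (0.05 log units; within the scatter). Compound 4 is estimated at 40 mL/min/kg, with an expected range of 22 mL/min/kg to 72 mL/min/kg.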

Compound 4, clearance: 16.8 mL/min/kg
Estimate against measurement, compound 4: 2.4-fold (0.38 log units) above; measured number below the stated range.
By their numbers in this assay, from the lowest: compounds 4, 1, 3 and 2 (each within the scatter of the next, the first and the last beyond it).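

In this assay this carbonyl carbon now shows steps beyond the scatter, both with the 5-cyanopyridin-2-yl group entering: a 2.7-fold lower number from compound 3 to compound 4 (0.43 log units; beyond the scatter) and a 2.9-fold lower number from compound 2 to compound 4 (0.46 log units; beyond the scatter). The group does not stand apart from every earlier one, as a 1.7-fold lower number from compound 1 to compound 4 (0.23 log units; within the scatter) stays within the scatter. Nothing measured here bears on the reason for these steps. The compounds shown leave open whether the nitrile or the pyridine ring carries the lower number. A plain pyridin-2-yl group on the same carbonyl carbon would separate the two.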